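Amino to Methylsulfonyl: Expected Solubility for Compound 4

The source may report more compounds than this note shows. Statements on the series, on what has been measured and on what is new or still open speak of the compounds shown alone.

Compound 1 `CS(=O)(=O)c1cccc(-c2ccc3ncc(-c4ccc(N)nc4)n3n2)c1` was tested in a physicochemical assay for solubility, at pH 6.5; on this read-out higher numbers stand for higher solubility and lower numbers for lower solubility. In this assay compound 1 reaches only a limit, < 5000 nM. Compound 3 `C[S+]([O-])c1cccc(-c2ccc3ncc(-c4ccc(C(N)=O)cc4)n3n2)c1` likewise gives only a limit, < 5000 nM. For the measured compounds named here, compound 2 `CS(=O)(=O)c1ccc(-c2cnc3ccc(-c4cccc(S(=O)(=O)CCO)c4)nn23)cc1` is the single compound with a full number, 8600 nM. Compound 1 therefore sits at the limit of < 5000 nM in this assay, at which 2 of the 3 values shown sit, so its exact place among the three cannot be read from the numbers. Compound 4 `CS(=O)(=O)c1cccc(-c2ccc3ncc(-c4ccc(S(C)(=O)=O)nc4)n3n2)c1` differs from compound 1 by one change, (methylsulfonyl in place of amino on an aromatic carbon), that is, methylsulfonyl in place of amino on an aromatic carbon. Going by the values given here, no comparable step between measured compounds exists, so the size of this step is open. The change from compound 1 to compound 4 is expected to be small, a number no lower from compound 1 to compound 4 (the limit leaves the size open), probably within the scatter. Compound 4 is estimated to give 5000 nM, with a range from 1500 nM to 16000 nM.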

Compound 4, solubility: < 5000 nM
Compound 4: a limit, no number; the forecaster's own chance of this, stated with the estimate: 55%; the middle value sits exactly at the limit.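

No step can be read from compound 1 to compound 4, since both reach only the same limit: the limit of < 5000 nM in this assay, at which 3 of the 4 values shown sit.

The compounds shown leave open how soluble compound 1 and compound 4 actually are, and how large the step from amino to methylsulfonyl is.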